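Removing a methyl from an aryl ether in two anilines

A few compounds are considered here, and "the series" means these few. Any claim that something is new, unique, unknown or untested is made for them only; others in the source may bear on it.

Two compounds share a core in which a cinnamate ester carries an aniline nitrogen linked through a benzylic carbon to a phenol ring. Compound 1 `COC(=O)/C=C/c1ccc(NCc2cc(Br)ccc2O)cc1` bears bromine on that ring, and in a functional assay on MDA-MB-231 cells (Homo sapiens) for antiproliferative activity, read by WST assay, with a stated time of 72 h (a higher number here means a weaker inhibitor, a lower number a stronger inhibitor), compound 1 gives 109000 nM. Compound 2 `COC(=O)/C=C/c1ccc(NCc2cccc(OC)c2O)cc1` carries a methoxy group instead, and in this assay compound 2 gives 73700 nM; its number and that of compound 1 lie within the scatter of each other, so neither can be called the stronger inhibitor.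

Compound 3 `COC(=O)/C=C/c1ccc(NCc2cccc(O)c2O)cc1` differs from compound 2 by a single change: hydrogen in place of methyl on an oxygen on an aromatic ring. Among the measured compounds shown here, no measured pair in this set shows such a step, so its direction is unknown. Given that compound 2 gives 73700 nM and compound 1 gives 109000 nM, the expected step from compound 2 to compound 3, a 1.0-fold higher number from compound 2 to compound 3 (0.01 log units; within the scatter), is none beyond the scatter. Compound 3 is therefore estimated at 75000 nM, with a range from 30000 nM to 190000 nM.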

Compound 3, half-maximal inhibitory concentration: 32600 nM
Beside the measured number, compound 3's estimate is 2.3-fold (0.36 log units) above it; the measured number falls inside the stated range.
By their numbers in this assay, from the lowest: compound 3; then compounds 2 and 1 (each within the scatter of the next).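

Methoxy to hydroxy gives the first single-change step in this series: in this assay the change reads as a 2.3-fold lower number from compound 2 to compound 3 (0.35 log units; beyond the scatter) and is modest in size. Among the compounds shown here, the earlier compounds held no such pair, so this step is the first sign that the group on this oxygen matters to the number, with hydrogen in place of methyl going with the lower value. Nothing measured here accounts for the step, so its cause stays unexplained.

The compounds shown leave open whether a larger group on the same oxygen, such as an ethyl or a longer chain, would move the number further in the opposite direction. They also leave open whether an amine in place of this hydroxy would keep the lower number, and whether the same step would appear with bromine on the ring.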